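The compounds below may be only part of what the source reports. "The series", "measured", "known", "first", "only" and "open" are said of these compounds alone.

Measured so far in a functional assay for antagonist activity at melanin-concentrating hormone receptor 1 (Homo sapiens); a higher number here means a weaker inhibitor, a lower number a stronger inhibitor:
Compound 1 `CC(C)N(CCN(C(=O)Nc1ccc(F)c(Cl)c1)C1CC[C@]2(c3cccc(C#N)c3)CC2C1)C(C)C` gives 4.98 nM.
Compound 2 `CCO/N=C/c1cccc([C@]23CCC(N(CCN(C(C)C)C(C)C)C(=O)Nc4ccc(F)c(Cl)c4)CC2C3)c1` gives 29 nM.
Compound 3 `CC(C)N(CCN(C(=O)Nc1ccc(F)c(Cl)c1)C1CC[C@]2(c3cccc(CNS(C)(=O)=O)c3)CC2C1)C(C)C` gives 18 nM.

Compound 3 stands second highest of these three numbers. Its nearest neighbour is compound 2, seen in a 1.6-fold lower number from compound 2 to compound 3 (0.21 log units; within the scatter), and its furthest is compound 1, seen in a 3.6-fold higher number from compound 1 to compound 3 (0.56 log units; beyond the scatter).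

Compound 4 `CC(=O)NCc1cccc([C@]23CCC(N(CCN(C(C)C)C(C)C)C(=O)Nc4ccc(F)c(Cl)c4)CC2C3)c1` differs from compound 3 in one place: acetyl in place of methylsulfonyl on an amine nitrogen. Among the compounds with values here, no measured step swaps these two groups, so the expectation rests only on how much the numbers moved when the group on this aromatic carbon was changed elsewhere: a 5.8-fold higher number from compound 1 to compound 2 (0.77 log units; beyond the scatter) and a 3.6-fold higher number from compound 1 to compound 3 (0.56 log units; beyond the scatter) were modest, and a 1.6-fold lower number from compound 2 to compound 3 (0.21 log units; within the scatter) stayed within the scatter.

A step of about a 1.1-fold higher number from compound 3 to compound 4 (0.05 log units; within the scatter) is therefore expected, with no clear direction beyond the scatter. Compound 4 is estimated at 20 nM, within 8 nM to 50 nM.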

Compound 4, inhibition constant: 31 nM
Beside the measured number, compound 4's estimate is 1.6-fold (0.19 log units) below it, within the range that was stated.
By their numbers in this assay, from the lowest: compound 1; then compounds 3, 2 and 4 (each within the scatter of the next).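

Changing methylsulfonyl to acetyl on this amine nitrogen gives a 1.7-fold higher number from compound 3 to compound 4 (0.24 log units; within the scatter) in this assay and stays within the scatter, so these two groups cannot be told apart here. Compound 4 also matches the group on the aromatic carbon of compound 2, with a 1.1-fold higher number from compound 2 to compound 4 (0.03 log units; within the scatter) within the scatter, while cyano keeps a real edge, shown by a 6.2-fold higher number from compound 1 to compound 4 (0.79 log units; beyond the scatter) beyond the scatter. Nothing available explains why these groups read alike.

As far as these compounds go, whether a longer chain in place of acetyl would shift the number remains open. So does whether a plain amine or a carboxylic acid on the aromatic carbon could match cyano.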